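Fluorine moved on the pendant phenyl of a thiazole series

A few compounds are considered here, and "the series" means these few. Any claim that something is new, unique, unknown or untested is made for them only; others in the source may bear on it.

Three compounds share one core, a methyl-thiazole carrying an aryl group and linked through an ether to a dihydrobenzofuran acetic acid. Compound 1 `Cc1nc(-c2cccc3ccccc23)sc1COc1ccc2c(c1)OCC2CC(=O)O` bears a naphthyl group, and in a functional assay on CHO cells for agonist activity at Free fatty acid receptor 1 (Homo sapiens), read by FLIPR and calcium flux (a higher number here means that more compound is needed for the effect, a lower number that less compound is needed), compound 1 is recorded as "not determined" (no result reported). Compound 2 `Cc1ccc(-c2nc(C)c(COc3ccc4c(c3)OCC4CC(=O)O)s2)cc1` bears a 4-methylphenyl group, and in this assay compound 2 gives 73.5 nM. Compound 3 `Cc1nc(-c2ccccc2F)sc1COc1ccc2c(c1)OCC2CC(=O)O` bears a 2-fluorophenyl group and, like compound 1, in this assay compound 3 is recorded as "not determined" (no result reported), so it cannot be placed against compound 2.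

Compound 4 `Cc1nc(-c2ccc(F)cc2)sc1COc1ccc2c(c1)OCC2CC(=O)O` arises from compound 3 by one rearrangement: 4-fluorophenyl in place of 2-fluorophenyl on an aromatic carbon. Among the compounds with values here, no measured pair shows how this kind of change plays out here, so no step size can be read from the data. Compound 4 resembles compound 2 in carrying its substituent at the same position of the phenyl ring, and on that basis its potency in this assay is expected to fall near that of compound 2, within the usual scatter. The value of compound 4 in this assay is estimated at 80 nM, ranging from 25 nM to 250 nM.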

Compound 4, half-maximal effective concentration: 48.7 nM
Compound 4: the middle estimate sits 1.6-fold (0.22 log units) above what was measured; low and high end bracket the measured number.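

Swapping the methyl of the 4-methylphenyl group for the fluoro of the 4-fluorophenyl group gives a 1.5-fold lower number from compound 2 to compound 4 (0.18 log units; within the scatter) in this assay, so the two groups cannot be told apart in this assay. Within the data shown here, this is the first readable step, and it shows that a measurable number is kept with either group on the phenyl ring. The effect of moving the fluorine itself cannot be read, and neither can any step involving compound 1, as compound 1 and compound 3 have no result. Nothing measured here accounts for this outcome.

The compounds shown leave open whether the 2-fluorophenyl group differs from the 4-fluorophenyl group in this assay. They also leave open whether a larger or charged group at the same ring position, such as a methoxy group, an amine or a carboxylic acid, would keep a similar number.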